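Ester to Amide at the Carbonyl of Compound 2

The source may hold more compounds than are shown below. What is called first, only, known or untested is meant among the compounds shown, and "the series" means these compounds.

Among three compounds measured in a functional assay on CHO cells for antagonist activity at sphingosine 1-phosphate receptor 2 (Homo sapiens), read by fluorescence and calcium flux, with a stated time of 3 min (on this read-out lower numbers stand for stronger inhibition and higher numbers for weaker inhibition), compound 2 `CCOC(=O)c1cc(C)cc(NNC(=O)Nc2cc(Cl)nc(Cl)c2)n1` gives the lowest number, 760 nM. Compound 1 `Cc1cc(NNC(=O)Nc2cc(Cl)nc(Cl)c2)ncc1N(C)C` gives 3600 nM and compound 3 `Cc1cc(NNC(=O)Nc2cc(Cl)nc(Cl)c2)ncc1-c1cnn(C)c1` gives 2600 nM; both lie beyond the scatter from compound 2. For the measured compounds named here, the one measured step, a 1.4-fold lower number from compound 1 to compound 3 (0.14 log units; within the scatter), changes a different place and stays within the scatter, so it does not bear on the move to compound 4 `Cc1cc(NNC(=O)Nc2cc(Cl)nc(Cl)c2)nc(C(=O)N(C)C2CC2)c1`. That move is cyclopropyl(methyl)amino in place of ethoxy on a carbonyl carbon. Going by the values given here, with no measured step at the carbonyl carbon, the step of a 1.2-fold higher number from compound 2 to compound 4 (0.07 log units; within the scatter) is expected to stay within the scatter, in either direction. Compound 4 is therefore estimated at 900 nM, with a range from 300 nM to 3000 nM in this assay.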

Compound 4, half-maximal inhibitory concentration: > 20000 nM
Compound 4: a limit, no number (the forecaster's own chance of this, stated with the estimate: 5%); middle value at least 22-fold (1.34 log units) away from the limit.
By their numbers in this assay, from the lowest: compound 2; then compounds 3 and 1 (each within the scatter of the next). At a limit, above all of these: compound 4.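

The carbonyl carbon proves to be a place where the attached group matters in this assay: cyclopropyl(methyl)amino in place of ethoxy gives an at least 26-fold higher number from compound 2 to compound 4 (1.42 log units; beyond the scatter). The only earlier step, at a different place, stayed within the scatter, so this is the one step shown that lies beyond it. The value of compound 4 is a limit: the limit of > 20000 nM in this assay, at which 1 of the 4 values shown sits.

The compounds shown leave open whether the change depends on this particular amine or on any amide at the carbonyl carbon. A simple methylamino group or a carboxylic acid there could separate these two readings.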